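This account rests on a few compounds, and the source may have more. Where it says the series, first, only, none or still open, it means among the compounds named here.

Of the compounds shown here, three sharing one core have been measured in an ADME assay on microsomes from liver (Homo sapiens) for pharmacokinetics, read by LC-MS, using NADPH, with a stated time of 45 min, tested at 1 uM (on this read-out higher numbers stand for fast clearance and lower numbers for slow clearance), so far. Compound 1 `COc1cc(OCc2ccnc(N)n2)cc2sc(N[C@H]3CCCC[C@@H]3O)nc12` gives 9.5 mL/min/kg in this test, the lowest of the three numbers. Compound 2 `COc1cc(OCc2ccnc(N)n2)c(Cl)c2sc(N[C@H]3CCCC[C@@H]3O)nc12` gives 33 mL/min/kg and compound 3 `COc1cc(OCc2ccnc(Nc3cn[nH]c3)n2)cc2sc(N[C@H]3CCCC[C@@H]3O)nc12` gives 32 mL/min/kg as its result. Compound 4 `COc1cc(OCc2ccnc(Nc3cn(C)nn3)n2)cc2sc(N[C@H]3CCCC[C@@H]3O)nc12` has not yet been measured.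

The change from compound 1 to compound 4 is 1-methyl-1H-1,2,3-triazol-4-yl in place of hydrogen on a nitrogen on an aromatic ring on the core. In words, 1-methyl-1H-1,2,3-triazol-4-yl takes the place of hydrogen on a nitrogen on an aromatic ring, so amino becomes (1-methyl-1H-1,2,3-triazol-4-yl)amino.

Among the measured compounds shown here, the closest precedent is a 3.4-fold higher number from compound 1 to compound 3 (0.53 log units; beyond the scatter) for the swap of 1H-pyrazol-4-yl for hydrogen on that same kind of nitrogen. The other measured step is a 3.5-fold higher number from compound 1 to compound 2 (0.54 log units; beyond the scatter) for chloro in place of hydrogen on an aromatic carbon, a different kind of place, so it offers only loose support. For the measured compounds named here, no compound with a triazole has been measured, and a single close precedent leaves the range wide.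

An upward move in this assay is therefore expected, of about the size seen for the pyrazole, and the estimate is a 2.9-fold higher number from compound 1 to compound 4 (0.47 log units; beyond the scatter) as the expected step. The estimated value for compound 4 is 28 mL/min/kg with an expected range from 14 mL/min/kg to 55 mL/min/kg around it.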

Compound 4, clearance: 43 mL/min/kg
Compound 4: middle estimate off by 1.5-fold (0.19 log units), on the low side; the measured number falls inside the stated range.
By their numbers in this assay, from the lowest: compound 1; then compounds 3, 2 and 4 (each within the scatter of the next).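

In this assay, putting 1-methyl-1H-1,2,3-triazol-4-yl on the amino nitrogen gives a 4.5-fold higher number from compound 1 to compound 4 (0.66 log units; beyond the scatter) and so moves the number the same way as the 1H-pyrazol-4-yl group of compound 3. The rise is therefore no longer tied to a single group: two different five-membered aromatic rings on this nitrogen both take clearance beyond the scatter of compound 1. Exchanging one ring for the other gives a 1.3-fold higher number from compound 3 to compound 4 (0.13 log units; within the scatter) and so the two cannot be told apart on this read-out, which means that the extra ring nitrogen and the methyl group, taken together, leave no visible mark here. Nothing available explains why either ring changes the clearance.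

On these data alone, both groups on this nitrogen are aromatic rings, so it remains open whether a simple methyl, an acetyl group or a longer alkyl chain in the same place would raise the number as well, or whether a ring is needed at all. As far as these compounds go, it is also open whether a phenyl ring, with no hetero atoms, would behave like these two rings.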